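Amine side chains, compound 1 to compound 4

The compounds below may be only part of what the source reports. "The series", "measured", "known", "first", "only" and "open" are said of these compounds alone.

In an ADME assay on the whole organism (strain FVB) for pharmacokinetics, with Mus musculus as the target, read by LC-MS, at a dose of 30 mg/kg by the oral route (a higher number here means more compound in the circulation at the dose given, a lower number less compound in the circulation), compound 1 `CC(C)(N)CCOc1ccc([C@H]2CC[C@]3(CC2)OOC2(O3)C3CC4CC(C3)CC2C4)cc1` gives 1050 nM, compound 2 `c1cc([C@H]2CC[C@]3(CC2)OOC2(O3)C3CC4CC(C3)CC2C4)ccc1OCCC1CCNCC1` gives 1190 nM and compound 3 `N[C@H]1CC[C@@H](Oc2ccc([C@H]3CC[C@]4(CC3)OOC3(O4)C4CC5CC(C4)CC3C5)cc2)CC1` gives 1170 nM. Compound 1 therefore cannot be separated from the other two. Compound 4 `NCCCCOc1ccc([C@H]2CC[C@]3(CC2)OOC2(O3)C3CC4CC(C3)CC2C4)cc1` is not yet measured and differs from compound 1 by 2-aminoethyl in place of 1-amino-1-methylethyl on a saturated chain carbon, two bonds along the chain from an oxygen on an aromatic ring, which also reads as 3-amino-3-methylbutoxy to 4-aminobutoxy. Two measured changes to the same side chain bear on this: a 1.1-fold higher number from compound 1 to compound 2 (0.05 log units; within the scatter) and a 1.1-fold higher number from compound 1 to compound 3 (0.05 log units; within the scatter). A third, a 1.0-fold lower number from compound 2 to compound 3 (0.01 log units; within the scatter), points the same way. Within the data shown here, no measured compound carries 4-aminobutoxy, so the range stays wide. The expected change is no larger than the scatter, with an estimated 1.1-fold lower number from compound 1 to compound 4 (0.02 log units; within the scatter). The estimate for compound 4 is 1000 nM, with an expected range of 500 nM to 2000 nM.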

Compound 4, maximal plasma concentration: 370 nM
The estimate for compound 4 lay 2.7-fold (0.43 log units) above the measured number; measured number below the stated range.
By their numbers in this assay, from the lowest: compound 4; then compounds 1, 3 and 2 (each within the scatter of the next).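

In this assay, the side chain on the oxygen is not neutral after all: the unbranched 4-aminobutoxy chain separates from the other three, with a 2.8-fold lower number from compound 1 to compound 4 (0.45 log units; beyond the scatter), a 3.2-fold lower number from compound 3 to compound 4 (0.50 log units; beyond the scatter) and a 3.2-fold lower number from compound 2 to compound 4 (0.51 log units; beyond the scatter). Among these four compounds, the higher numbers go with the branched chain of compound 1 and the ring-bearing chains of compound 2 and compound 3, and no compound goes against this. No supporting measurement accounts for the drop. Open, going by these compounds, is whether a single methyl group on the 4-aminobutyl chain gives a number like that of compound 1. On these data alone, a shorter unbranched amine chain is also open.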